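Amide side chain swap on the core of compound 3

This account rests on a few compounds, and the source may have more. Where it says the series, first, only, none or still open, it means among the compounds named here.

Compound 3 `Cn1cc(CNC(=O)c2ccncc2Nc2cc(-c3ccc4ccn(C)c4c3)c3nccnc3c2)cn1` gives 0.267 h in an ADME assay on microsomes from liver (Mus musculus, strain CD-1) for metabolic stability, read by LC-MS, tested at 2 uM; a lower number here means that the compound disappears faster, a higher number that the compound lasts longer. That number lies within the scatter of compound 2 `Cn1ccc2ccc(-c3cc(Nc4ccccc4S(=O)(=O)NCC4CCOCC4)cc4nccnc34)cc21`, which gives 0.3 h in this assay. Compound 1 `CN1CCC(CNS(=O)(=O)c2ccccc2Nc2cc(-c3ccc4ccn(C)c4c3)c3nccnc3c2)C1` gives 0.633 h in this assay, and compound 3 stands beyond the scatter below it. Compound 4 `CN1CC(NC(=O)c2ccncc2Nc2cc(-c3ccc4ccn(C)c4c3)c3nccnc3c2)C1` differs from compound 3 in one place: 1-methylazetidin-3-yl in place of (1-methyl-1H-pyrazol-4-yl)methyl on an amide-type nitrogen. Among the compounds with values here, the only measured step, a 2.1-fold lower number from compound 1 to compound 2 (0.32 log units; beyond the scatter), swaps a ring on a saturated chain carbon bound to a sulfonamide nitrogen rather than a group on an amide-type nitrogen, so it bears only loosely on this change, though it shows that such a swap can shift the number modestly. Compound 4 is therefore expected to show a step of a 1.3-fold higher number from compound 3 to compound 4 (0.12 log units; within the scatter), within the scatter. Compound 4 is estimated at 0.35 h, between 0.18 h and 0.7 h.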

Compound 4, half-life: > 1 h
Compound 4 gave a limit, no number (the forecaster's own chance of this, stated with the estimate: 5%); middle value at least 2.8-fold (0.45 log units) away from the limit.
By their numbers in this assay, from the lowest: compounds 3 and 2 (each within the scatter of the next); then compound 1. At a limit, above all of these: compound 4.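

The amide-type nitrogen proved to be a position where the group carried can shift the half-life beyond the scatter: 1-methylazetidin-3-yl in place of (1-methyl-1H-pyrazol-4-yl)methyl gives an at least 3.7-fold higher number from compound 3 to compound 4 (0.57 log units; beyond the scatter) in this assay. Compound 4 sits at a limit of the assay, not at a number, and it alone among the compounds shown does so: the limit of > 1 h in this assay, at which 1 of the 4 values shown sits.

The compounds shown leave open how far compound 4 lies past that limit. They also leave open whether an azetidin-3-yl without the methyl, or an open-chain 2-(dimethylamino)ethyl, on the same nitrogen would last as long.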